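Piperidin-1-yl in place of acetamido on the shared core

This account rests on a few compounds, and the source may have more. Where it says the series, first, only, none or still open, it means among the compounds named here.

In a functional assay on HCT-116 cells (Homo sapiens) for inhibition (a lower number here means a stronger inhibitor, a higher number a weaker inhibitor), compound 1 (`CCNC(=O)c1noc(-c2cc(C(C)C)c(O)cc2O)c1-c1cc(COCC(=O)OC)no1`) gives 262 nM. The result for compound 2 (`CCNC(=O)c1noc(-c2cc(C(C)C)c(O)cc2O)c1-c1cc(COCC(=O)O)no1`) stands as "not determined" (no result reported), so compound 2 adds no number to the comparison. Compound 3 (`CCNC(=O)c1noc(-c2cc(C(C)C)c(O)cc2O)c1-c1cc(CNC(C)=O)no1`) gives 167 nM. Going by the values given here, only two numbers therefore exist in this assay, and they lie within the scatter of each other, so compound 3 has no clear standing over compound 1.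

Compound 4 (`CCNC(=O)c1noc(-c2cc(C(C)C)c(O)cc2O)c1-c1cc(CN2CCCCC2)no1`) carries piperidin-1-yl in place of acetamido on a saturated chain carbon bound to an aromatic carbon.

Among the compounds with values here, one measured step bears on this change, as it alters the same carbon: a 1.6-fold lower number from compound 1 to compound 3 (0.20 log units; within the scatter). That step stays within the scatter, although the two groups it exchanges differ considerably. Within the data shown here, it is only a loose guide, since no measured compound carries piperidin-1-yl or any other ring at this carbon. No shift beyond the scatter is therefore expected in this assay, and no direction is favoured with confidence. The expected change is a 1.1-fold lower number from compound 3 to compound 4 (0.05 log units; within the scatter). For compound 4 the estimate is 150 nM, with an expected range from 50 nM to 450 nM.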

Compound 4, half-maximal inhibitory concentration: 93 nM
Compound 4: middle estimate off by 1.6-fold (0.21 log units), on the high side, and the stated range covers the measured number.
By their numbers in this assay, from the lowest: compounds 4, 3 and 1 (each within the scatter of the next, the first and the last beyond it).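

In this assay the saturated chain carbon bound to an aromatic carbon now carries a ring, and the exchange of acetamido for piperidin-1-yl gives a 1.8-fold lower number from compound 3 to compound 4 (0.25 log units; within the scatter), which stays within the scatter, so this position accepts a six-membered non-aromatic ring with 0 hydrogen-bond donors without a clear shift from the acetamido result. Going by these compounds alone, the comparison with the ester side chain is the first at this carbon to clear the scatter: the exchange of (methoxycarbonyl)methoxy for piperidin-1-yl gives a 2.8-fold lower number from compound 1 to compound 4 (0.45 log units; beyond the scatter), a modest step, and it separates only the two ends of the series, since compound 3 lies within the scatter of both compound 1 and compound 4. No measurement on hand accounts for these steps.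

Open, as far as these compounds go, is whether the number of compound 4 goes with the ring or with the amine nitrogen on this carbon, a question that an open-chain dimethylamino group or a morpholin-4-yl ring at the same place would bear on. Also open, from the compounds shown here alone, is how far the series tolerates a longer chain between the aromatic carbon and the piperidin-1-yl ring.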